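Adding a Second Fluorine: Cytotoxicity Outlook for Compound 4

The compounds below may be only part of what the source reports. "The series", "measured", "known", "first", "only" and "open" are said of these compounds alone.

Compound 1 `CC(C)n1ncc2c(C(=O)Nc3cccc(F)c3)cc(-c3cccs3)nc21` carries a 3-fluorophenyl group on the shared core. In an ADME assay on LLC-MK2 cells (Macaca mulatta) for cytotoxicity, read by spectrophotometry and crystal violet staining, with a stated time of 4 days (a higher number here means that more compound is tolerated, a lower number that less compound is tolerated), compound 1 gives > 200000 nM, which is a limit of the assay rather than a number. Two close relatives have been run the same way. Compound 2 `CC(C)n1ncc2c(C(=O)Nc3ccc(F)cc3)cc(-c3ccsc3)nc21` gives > 200000 nM in this assay, again a limit. Compound 3 `CC(C)n1ncc2c(C(=O)Nc3cccc(S(=O)(=O)N(C)C)c3)cc(-c3cccs3)nc21` gives > 200000 nM in this assay, also a limit. Within the data shown here, the only measured step that touches compound 1, a step that the two limits leave unreadable from compound 1 to compound 3, is therefore of unreadable size, and the limit of > 200000 nM in this assay, at which 3 of the 3 values shown sit, means that compound 1 cannot be ranked against compounds 2 or 3 on these numbers; it simply stands at the limit with them.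

Compound 4 `CC(C)n1ncc2c(C(=O)Nc3ccc(F)c(F)c3)cc(-c3cccs3)nc21` differs from compound 1 by fluoro in place of hydrogen on an aromatic carbon. Among the measured compounds shown here, no measured step covers this change, so the expectation rests on the three limits alone. Because the limit of > 200000 nM in this assay, at which 3 of the 3 values shown sit, holds for compounds 1, 2 and 3 alike, compound 4 is expected to sit at the same limit, with an expected step of a number no higher from compound 1 to compound 4 (the limit leaves the size open) that is none beyond the scatter. Compound 4 is thus estimated at 200000 nM in this assay, within an expected range from 100000 nM to 400000 nM.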

Compound 4, half-maximal cytotoxic concentration: > 200000 nM
Compound 4 was reported as a limit; the forecaster's own chance of this, stated with the estimate: 85%; the middle value lies on the limit itself.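

In this assay compound 4 gives > 200000 nM, which is a limit of the assay and not a number. No step can be read from compound 1 to compound 4, since the result adds one more compound to the same limit: the limit of > 200000 nM in this assay, at which 4 of the 4 values shown sit. The compounds shown leave open where each half-maximal cytotoxic concentration truly lies, and whether fluoro in place of hydrogen changes it at all.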